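Swapping bromo for phenoxy on an aromatic carbon

A few compounds are considered here, and "the series" means these few. Any claim that something is new, unique, unknown or untested is made for them only; others in the source may bear on it.

- Compound 1 `CSc1ccccc1C1=NC(c2ccccc2)CO1`: 3.5
- Compound 2 `Ic1ccccc1C1=NC(c2ccccc2)CO1`: 3.86
- Compound 3 `Brc1ccccc1C1=NC(c2ccccc2)CO1`: 3.69

In a physicochemical assay for lipophilicity (on this read-out higher numbers stand for higher lipophilicity and lower numbers for lower lipophilicity), compound 3 gives 3.69 and cannot be told apart from either of the other two compounds. The steps that connect it to them are a number 0.19 log units higher from compound 1 to compound 3 (within the scatter) and a number 0.17 log units lower from compound 2 to compound 3 (within the scatter). Among the compounds with values here, only one measured step clears the usual scatter: a number 0.36 log units higher from compound 1 to compound 2 (beyond the scatter).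

The next compound is compound 4 `c1ccc(Oc2ccccc2C2=NC(c3ccccc3)CO2)cc1`, and the change is phenoxy in place of bromo on an aromatic carbon. In words, this is phenoxy in place of bromo on an aromatic carbon, ortho to a large group.

Within the data shown here, none of the measured steps brings in a ring, so they offer only a loose guide, and the data hold no direct precedent. Even so, a rise in this assay is expected, larger than the modest step from methylsulfanyl to iodo. The expected change is a number 0.71 log units higher from compound 3 to compound 4 (beyond the scatter). For compound 4 the estimated value is 4.4, with an expected range from 3.9 to 4.9.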

Compound 4, partition coefficient: 5.61
Estimate against measurement, compound 4: 1.21 log units below, outside the stated range (above it).
By their numbers in this assay, from the lowest: compounds 1, 3 and 2 (each within the scatter of the next, the first and the last beyond it); then compound 4.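

Phenoxy, on an aromatic carbon ortho to a large group, sets compound 4 well apart in this assay: the steps are a number 1.92 log units higher from compound 3 to compound 4 (beyond the scatter) and a number 1.75 log units higher from compound 2 to compound 4 (beyond the scatter) and also a number 2.11 log units higher from compound 1 to compound 4 (beyond the scatter) and each of them counts as large. Within the data shown here, the numbers at this position therefore span a far wider range than the three earlier compounds showed, and phenoxy is the only group here that brings in a ring. No evidence at hand explains the size of this rise.

From the compounds shown here alone, what stays open is how much of the rise belongs to the ring and how much to the oxygen that joins it to the core, and a methoxy group or a plain phenyl group at this position would help to separate the two. Going by these compounds, how an amine or a carboxylic acid here would read in this assay also remains open.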